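The source may report more compounds than this note shows. Statements on the series, on what has been measured and on what is new or still open speak of the compounds shown alone.

Compound 1 `Cc1cn(C2CCN(Cc3cccc(Oc4ccccc4)n3)CC2)c(=O)[nH]c1=O` gives > 64000 nM in an ADME assay on MRC5 cells (Homo sapiens) for cytotoxicity, read by fluorescence and resazurin assay, with a stated time of 3 days; on this read-out lower numbers stand for stronger inhibition and higher numbers for weaker inhibition.
Compound 2 `Cc1cn(C2CCN(Cc3cccc(Oc4ccc(Cl)c(Cl)c4)c3)CC2)c(=O)[nH]c1=O` gives 6100 nM in this assay.

The value of compound 1 is a limit of the assay, not a number, as the limit of > 64000 nM in this assay, at which 1 of the 2 values shown sits, records. Among the compounds with values here, compound 2 therefore holds the only number measured so far in this assay. Compound 3 `Cc1cn(C2CCN(Cc3cccc(Oc4ccc(Cl)c(C(F)(F)F)c4)c3)CC2)c(=O)[nH]c1=O` differs from compound 2 in one place: trifluoromethyl in place of chloro on an aromatic carbon. Within the data shown here, no step between measured compounds exists for comparison, so the change from compound 2 to compound 3 in this assay is expected to stay within the usual scatter. Compound 3 is estimated at 5000 nM, between 2000 nM and 15000 nM. The expected step is a 1.2-fold lower number from compound 2 to compound 3 (0.09 log units; within the scatter).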

Compound 3, half-maximal inhibitory concentration: 5280 nM
Estimate against measurement, compound 3: 1.1-fold (0.02 log units) below; the measured number falls inside the stated range.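

In this assay, within the data shown here, the exchange of chloro for trifluoromethyl on this aromatic carbon, ortho to a chloro group, reads as a 1.2-fold lower number from compound 2 to compound 3 (0.06 log units; within the scatter) and gives the first comparison between two numbers. At this position, therefore, 3,4-dichlorophenyl and 4-chloro-3-(trifluoromethyl)phenyl cannot be told apart on this read-out, and the larger group leaves the cytotoxicity reading within the scatter.

On these data alone, whether an amine or a carboxylic acid on this carbon would also stay within the scatter of compound 2 remains open. No measurement shown bears on the cause of this step.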